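Hydroxy on the Piperidine of a Benzamide Kinase Inhibitor

The source may hold more compounds than are shown below. What is called first, only, known or untested is meant among the compounds shown, and "the series" means these compounds.

Measured compounds:
compound 1 `O=C(Nc1ccnnc1)c1cc(N2CCCCC2)ccc1OCc1ccccc1`, 25.1 nM
compound 2 `O=C(Nc1cccc(F)c1)c1cc(C(F)(F)F)ccc1OCc1ccc(F)cc1`, 31.6 nM

In an assay on Sf9 cells for inhibition of Leucine-rich repeat serine/threonine-protein kinase 2 (Homo sapiens), read by TR-FRET, with stated times of 30 min and 2 h (on this read-out higher numbers stand for weaker inhibition and lower numbers for stronger inhibition), compound 1 gives 25.1 nM, and compound 2 gives 31.6 nM; the two numbers sit within the usual scatter of each other, so no order between them can be read. Compound 3 `O=C(Nc1ccnnc1)c1cc(N2CCC(O)CC2)ccc1OCc1ccccc1` differs from compound 1 by hydroxy in place of hydrogen on a saturated ring carbon. Among the measured compounds shown here, no measured pair shows this change, so the step of a 1.2-fold higher number from compound 1 to compound 3 (0.08 log units; within the scatter) is only an expectation, and no move beyond the scatter is expected in either direction. Compound 3 is therefore estimated at 30 nM, within 10 nM to 100 nM.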

Compound 3, half-maximal inhibitory concentration: 39.8 nM
Beside the measured number, compound 3's estimate is 1.3-fold (0.12 log units) below it; low and high end bracket the measured number.
By their numbers in this assay, from the lowest: compounds 1, 2 and 3 (each within the scatter of the next).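

In this assay, putting 4-hydroxypiperidin-1-yl in place of piperidin-1-yl gives a 1.6-fold higher number from compound 1 to compound 3 (0.20 log units; within the scatter). This first measured pair for the change shows that a hydroxy on this saturated ring carbon, three ring bonds from the ring nitrogen, leaves the number within the scatter, so the position accepts this group without a readable loss. Nothing measured here explains this result.

As far as these compounds go, whether a methoxy, an amine or a carboxylic acid on the same ring carbon would also keep the number there remains open. So does the outcome for a hydroxy on another carbon of the ring.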